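The source may report more compounds than this note shows. Statements on the series, on what has been measured and on what is new or still open speak of the compounds shown alone.

The study turns on a single change tested in a functional assay on NIH3T3 cells for agonist activity at Urotensin-2 receptor (Homo sapiens), with a stated time of 5 days; on this read-out lower numbers stand for an effect already at smaller amounts and higher numbers for an effect only at larger amounts of compound. Compound 2 `CN(C)CCC(NC(=O)/C=C/c1ccccc1)c1ccc(Cl)cc1` gives 427 nM in this assay. Compound 1 `Cc1ccc(C(CCN(C)C)NC(=O)/C=C/c2ccccc2)cc1` differs from compound 2 by one change, (methyl in place of chloro on an aromatic carbon), and in this assay compound 1 gives 1550 nM, a shift of a 3.6-fold higher number from compound 2 to compound 1 (0.56 log units; beyond the scatter). Compound 3 `COc1ccc(CCC(=O)NC(CCN(C)C)c2ccc(Cl)cc2)cc1` carries a different core; how that core differs from the core of compound 2 is not broken down here. In this assay compound 3 gives 2950 nM, the highest of the three numbers, though its gap to compound 1 lies within the usual scatter.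

Compound 4 `COc1ccc(CCC(=O)NC(CCN(C)C)c2ccc(C)cc2)cc1` has not yet been measured. Among the compounds with values here, it differs from compound 3 by methyl in place of chloro on an aromatic carbon, the same change, at the same place, as the one from compound 2 to compound 1. Within the data shown here, because the only precedent for this change is a 3.6-fold higher number from compound 2 to compound 1 (0.56 log units; beyond the scatter), compound 4 is expected to move by about a 3.1-fold higher number from compound 3 to compound 4 (0.48 log units; beyond the scatter). Compound 4 is accordingly estimated at 9000 nM in this assay, with an expected range from 3000 nM to 25000 nM, a wide span since it rests on one step on a different core.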

Compound 4, half-maximal effective concentration: 5370 nM
Beside the measured number, compound 4's estimate is 1.7-fold (0.22 log units) above it; measured number inside the range.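

In this assay, the change from chloro to methyl on the core of compound 3 comes to a 1.8-fold higher number from compound 3 to compound 4 (0.26 log units; within the scatter), so on this core alone the step cannot be told apart from repeat measurement. Set beside the earlier step, the two readings do not differ beyond what repeated measurements allow: the same change on two cores in this assay, a 3.6-fold higher number (0.56 log units; beyond the scatter) from compound 2 to compound 1 and a 1.8-fold higher number (0.26 log units; within the scatter) from compound 3 to compound 4, 2.0-fold (0.30 log units) apart, within the scatter of two such steps. This shows that the change can be carried between these two cores without a detectable disagreement in its size, but it does not show that the step is truly the same on both, and two cores, one of them with a step inside the scatter, give no rule for the series.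

The compounds shown leave open whether other groups at this place on the aromatic ring, such as fluoro or trifluoromethyl, would behave alike on both cores. They also leave open whether the step would hold with a diethylamino group in place of the dimethylamino group.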